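This account rests on a few compounds, and the source may have more. Where it says the series, first, only, none or still open, it means among the compounds named here.

Series notes. Compound 2 `c1ccc(Oc2ccc3c(NCCCNCc4ccco4)ccnc3c2)cc1` gives 14500 nM in a physicochemical assay for solubility, with a stated time of 18 h, at pH 7.4 (on this read-out higher numbers stand for higher solubility and lower numbers for lower solubility), the lowest of the two numbers in hand; its nearest neighbour is compound 1 `COc1ccc(-c2ccc3c(NCCCNCc4cccc(OC)c4O)ccnc3c2)cc1`, which in this assay gives 32000 nM, a gap beyond the scatter. Compound 3 `COc1ccc(-c2ccc3c(NCCCNCc4ccco4)ccnc3c2)cc1` is not yet measured in this assay. Relative to compound 2 it carries 4-methoxyphenyl in place of phenoxy on an aromatic carbon. For the measured compounds named here, compound 1 also carries the 4-methoxyphenyl group but differs at the amine end as well, so no single measured step isolates this change. A small shift in either direction, or none beyond the scatter, is expected for a 1.2-fold higher number from compound 2 to compound 3 (0.09 log units; within the scatter). Compound 3 is estimated at 18000 nM, within a range of 6000 nM to 50000 nM.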

Compound 3, solubility: 32000 nM
Beside the measured number, compound 3's estimate is 1.8-fold (0.25 log units) below it; the range from low to high includes it.
By their numbers in this assay, from the lowest: compound 2; then compounds 1 and 3 (each within the scatter of the next).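

On this assay the swap to 4-methoxyphenyl in place of phenoxy on an aromatic carbon now has a step of its own, a 2.2-fold higher number from compound 2 to compound 3 (0.34 log units; beyond the scatter) and that step is modest. Furan-2-yl in place of 2-hydroxy-3-methoxyphenyl on a saturated chain carbon bound to an amine nitrogen shows no change at the digits printed from compound 1 to compound 3 (within the scatter) so with 4-methoxyphenyl held, this swap does not separate the two compounds. Nothing at hand gives a cause for either step.

Open, from the compounds shown here alone, is whether the step from phenoxy holds with 2-hydroxy-3-methoxyphenyl on the chain. Also open, going by these compounds, is how a carboxylic acid or a morpholine on that aromatic carbon would read.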